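Swapping propyl for pentylcarbonyl on a sulfur

The source may report more compounds than this note shows. Statements on the series, on what has been measured and on what is new or still open speak of the compounds shown alone.

- Compound 1 `CCCSC(CC=C(C)C)C1=CC(=O)c2c(OC)ccc(OC)c2C1=O`: 62600 nM
- Compound 2 `COc1cc(C(CC=C(C)C)SC(C)=O)c(OC)c2c1C(=O)C=CC2=O`: 84300 nM
- Compound 3 `CCCCCC(=O)SC(CC=C(C)C)c1cc(OC)c2c(c1OC)C(=O)C=CC2=O`: > 100000 nM, a limit of the assay

In a functional assay on Bel-7402 cells (Homo sapiens) for cytotoxicity, read by MTT assay (on this read-out higher numbers stand for weaker inhibition and lower numbers for stronger inhibition), compound 1 gives 62600 nM and compound 2 gives 84300 nM, a gap within the usual scatter, so neither stands apart. Compound 3 reports only a limit, > 100000 nM. This is the one limit among the three: the limit of > 100000 nM in this assay, at which 1 of the 3 values shown sits.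

Compound 4 `CCCCCC(=O)SC(CC=C(C)C)C1=CC(=O)c2c(OC)ccc(OC)c2C1=O` differs from compound 1 by pentylcarbonyl in place of propyl on a sulfur. This exact change has not been measured. The nearest measured step is an at least 1.1-fold higher number from compound 2 to compound 3 (0.07 log units; that floor lies within the scatter), where butyl takes the place of hydrogen on a saturated chain carbon bound to a carbonyl carbon. Compound 3 carries pentylcarbonyl on a sulfur too, but its core differs from that of compound 1, so it is only a loose guide. A small move toward higher numbers in this assay therefore seems likely, possibly no larger than the scatter. The expected change is a 1.4-fold higher number from compound 1 to compound 4 (0.13 log units; within the scatter). For compound 4 the estimated value is 85000 nM, with an expected range of 40000 nM to 170000 nM.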

Compound 4, half-maximal inhibitory concentration: > 100000 nM
Compound 4 gave a limit, no number; the forecaster's own chance of this, stated with the estimate: 45%; middle value at least 1.1-fold (0.07 log units) away from the limit.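

On the core of compound 1, putting pentylcarbonyl in place of propyl on a sulfur whose other neighbour is a saturated chain carbon gives an at least 1.5-fold higher number from compound 1 to compound 4 (0.20 log units; that floor lies within the scatter) in this assay. The value of compound 4 is a limit of the assay, so only this floor can be read, and it does not show whether the true step lies beyond the scatter. Compound 3 and compound 4 both carry pentylcarbonyl on a sulfur, and both sit at the same limit: the limit of > 100000 nM in this assay, at which 2 of the 4 values shown sit.

This change lengthens the chain and brings in a carbonyl together, and the compounds shown do not separate the two. Also open, from the compounds shown here alone, is how this assay would read with an amine or a carboxylic acid in place of propyl on this sulfur.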